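This account rests on a few compounds, and the source may have more. Where it says the series, first, only, none or still open, it means among the compounds named here.

Compound 1 (`CCn1ccnc1-c1cc(OC)c(OC)c(OC)c1`), compound 2 (`CCCCCn1ccnc1-c1cc(OC)c(OC)c(OC)c1`) and compound 3 (`COc1cc(-c2nccn2S(=O)(=O)c2ccc(C)cc2)cc(OC)c1OC`) share one core and differ in the group on an aromatic nitrogen. In a functional assay on HeLa cells (Homo sapiens) for antiproliferative activity, read by MTT assay, with a stated time of 72 h (a lower number here means a stronger inhibitor, a higher number a weaker inhibitor), compound 2 gives > 100000 nM, which is a limit and not a number. Compound 1 gives > 100000 nM, likewise only a limit. Compound 3 gives > 100000 nM, again only a limit. Together these results show (the limit of > 100000 nM in this assay, at which 3 of the 3 values shown sit), so compound 2 has no number of its own to stand on. Among the compounds with values here, the one measured step, a step that the two limits leave unreadable from compound 1 to compound 2, has no readable size and gives no guide to how much this group matters.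

Compound 4 (`COc1cc(-c2nccn2-c2ccc(Br)cc2)cc(OC)c1OC`) keeps the shared core and changes that group: 4-bromophenyl in place of pentyl on an aromatic nitrogen. Within the data shown here, no measured step covers this exchange of 4-bromophenyl for pentyl, and no compound so far has given a number. The expectation in this assay is therefore cautious: at best a modest move towards stronger inhibition, and quite possibly another limit. The estimated step is an at least 3.3-fold lower number from compound 2 to compound 4 (0.52 log units; beyond the scatter). For compound 4 the expected value is 30000 nM, with an estimated range of 5000 nM to 100000 nM.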

Compound 4, half-maximal inhibitory concentration: 3300 nM
The estimate for compound 4 lay 9.1-fold (0.96 log units) above the measured number; the measured number lies below the stated range.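

The group on an aromatic nitrogen of the shared core proves able to bring a readable number in this assay: compound 4 is the only compound shown that gives a value and not a limit. The exchange of pentyl for 4-bromophenyl is an at least 30-fold lower number from compound 2 to compound 4 (1.48 log units; beyond the scatter), and the exchange of ethyl for the same group is an at least 30-fold lower number from compound 1 to compound 4 (1.48 log units; beyond the scatter), so both steps are large, and each has a limit at its starting end and therefore gives only a minimum size. Compound 4 thus stands apart from the other compounds, and the shared core alone does not yield a number, nor does it with ethyl or pentyl on that nitrogen: the limit of > 100000 nM in this assay, at which 3 of the 4 values shown sit.

From the compounds shown here alone, whether the six-membered aromatic ring or the bromine carries the change stays open, and a plain phenyl or a 4-chlorophenyl on the same nitrogen would separate the two. Going by these compounds, how an amine or a carboxylic acid on that ring would read in this assay also remains open, as does the full size of both steps.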